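A few compounds are considered here, and "the series" means these few. Any claim that something is new, unique, unknown or untested is made for them only; others in the source may bear on it.

Of the compounds shown here, three have been measured in a functional assay on CHO cells for antagonist activity at sphingosine 1-phosphate receptor 2 (Homo sapiens), read by calcium flux; a lower number here means a stronger inhibitor, a higher number a weaker inhibitor. Compound 1 `COc1cc(OC)c(NC(=O)Cn2nc(CC(=O)O)c3ccccc32)cc1Cl` gives 3360 nM in this assay. Compound 2 `C[C@@H](C(=O)O)c1nn(Cc2cn3cc(OCC4CC4)c(Cl)cc3n2)c2ccccc2c1=O` gives 24 nM. Compound 3 `CCC(C(=O)O)c1nn(Cc2cn3cc(OCC4CC4)c(Cl)cc3n2)c2ccccc2c1=O` gives 5.6 nM, the lowest of the three numbers; the nearest to it is compound 2 and the furthest is compound 1. Among the compounds with values here, the only step between two measured compounds that differ in one place is a 4.3-fold lower number from compound 2 to compound 3 (0.63 log units; beyond the scatter). Compound 4 `CC(C)(C(=O)O)c1nn(Cc2cn3cc(OCC4CC4)c(Cl)cc3n2)c2ccccc2c1=O` differs from compound 3 by 1-carboxy-1-methylethyl in place of 1-carboxypropyl on an aromatic carbon. Within the data shown here, no measured pair shows a rearrangement of this kind, so the step from compound 2 to compound 3 is the only guide, and it concerns a change in chain length rather than the present rearrangement of the same atoms. The gain seen there cannot simply be carried over. The number for compound 4 is therefore expected to sit somewhat higher than that of compound 3, the expected step being a 2.7-fold higher number from compound 3 to compound 4 (0.43 log units; beyond the scatter). Compound 4 is estimated at 15 nM, within a range from 4 nM to 60 nM.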

Compound 4, half-maximal inhibitory concentration: 7.7 nM
Estimate against measurement, compound 4: 1.9-fold (0.29 log units) above; measured number inside the range.
By their numbers in this assay, from the lowest: compounds 3 and 4 (each within the scatter of the next); then compound 2; then compound 1.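

In this assay, rearranging the same atoms from 1-carboxypropyl to 1-carboxy-1-methylethyl gives a 1.4-fold higher number from compound 3 to compound 4 (0.14 log units; within the scatter) and so leaves the two groups indistinguishable at this position on the aromatic carbon. Within the data shown here, what the earlier compounds could not show is that the gain over 1-carboxyethyl does not depend on a straight chain, since a 3.1-fold lower number from compound 2 to compound 4 (0.49 log units; beyond the scatter) goes the same way as the step already seen to compound 3. No measurement shown here explains this result.

From the compounds shown here alone, it remains open whether a longer chain such as 1-carboxybutyl, or a ring closed at the same carbon such as 1-carboxycyclopropyl, would keep the number in this range. Also open, going by these compounds, is whether an amide or a tetrazole could stand in place of the carboxylic acid.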